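Moving the phenyl around the benzamide ring in a cathepsin S series

A few compounds are considered here, and "the series" means these few. Any claim that something is new, unique, unknown or untested is made for them only; others in the source may bear on it.

Measured compounds:
compound 1 `COc1ccc(NCCNC(=O)[C@@H](NC(=O)c2cccc(C)c2)C2CCCCC2)cc1` 23 nM
compound 2 `COc1ccc(NCCNC(=O)[C@H](CC2CCCCC2)NC(=O)c2cccc(-c3ccccc3)c2)cc1` 2.9 nM

Of the compounds shown here, two have been measured in an assay on isolated protein for inhibition of cathepsin S (Homo sapiens), at 37 degrees C, at pH 5.5; a higher number here means a weaker inhibitor, a lower number a stronger inhibitor. Compound 1 gives 23 nM in this assay, and compound 2 gives 2.9 nM, which is the lower of the two numbers; the gap between them lies beyond the scatter. Going by the values given here, compounds 1 and 2 differ in more than one place, so their two values show only that compound 2 is the stronger inhibitor of the pair, not which change carries the gain.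

Compound 3 `COc1ccc(NCCNC(=O)[C@H](CC2CCCCC2)NC(=O)c2ccc(-c3ccccc3)cc2)cc1` has not yet been measured. It differs from compound 2 in a single place: 4-phenylphenyl in place of 3-phenylphenyl on a carbonyl carbon. Among the compounds with values here, no measured pair in this set shows what such a change does, so its effect in this assay can only be judged as an expectation. The account expects a small step from compound 2 to compound 3, of the size a 1.7-fold higher number from compound 2 to compound 3 (0.24 log units; within the scatter), possibly toward a weaker inhibitor but likely within or close to the scatter. Compound 3 is therefore expected to give about 5 nM in this assay, with a range from 1.5 nM to 20 nM.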

Compound 3, inhibition constant: 9.1 nM
Compound 3: middle estimate off by 1.8-fold (0.26 log units), on the low side, within the range that was stated.
By their numbers in this assay, from the lowest: compound 2; then compound 3; then compound 1.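

Going by these compounds alone, this is the first pair in the set that differs in one place, and it gives this position a measured effect: in this assay, 4-phenylphenyl in place of 3-phenylphenyl on a carbonyl carbon gives a 3.1-fold higher number from compound 2 to compound 3 (0.50 log units; beyond the scatter). The two groups hold the same atoms and the same counts of rings, donors and acceptors, and only the point at which the outer phenyl is joined differs, yet that alone moves the number beyond the scatter, with 3-phenylphenyl giving the stronger inhibitor of this pair. Nothing measured on these compounds accounts for the size or direction of this step.

On these data alone, whether an amine or a carboxylic acid on the outer phenyl, or a pyridine ring in its place, would keep, widen or close this gap remains open. Also open, as far as these compounds go, is how much of the distance to compound 1 belongs to the group on the carbonyl carbon and how much to the cyclohexyl side of the molecule, since compound 1 differs from compound 2 and compound 3 in more than one place.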